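The source may report more compounds than this note shows. Statements on the series, on what has been measured and on what is new or still open speak of the compounds shown alone.

Measured so far in a functional assay on HepG2 cells (Homo sapiens) for antiproliferative activity, read by MTT assay, with a stated time of 72 h; a lower number here means a stronger inhibitor, a higher number a weaker inhibitor:
Compound 1 `C=C(F)C(=O)Nc1cc(Nc2nccc(-c3cn(C)c4ccccc34)n2)c(OC)cc1N(C)CCN(C)C` gives 3790 nM.
Compound 2 `CCC/C=C\C(=O)Nc1cc(Nc2nccc(-c3cn(C)c4ccccc34)n2)c(OC)cc1N(C)CCN(C)C` gives 431 nM.

Compound 2 has the lowest of the two numbers; its nearest neighbour is compound 1, and the step of an 8.8-fold lower number from compound 1 to compound 2 (0.94 log units; beyond the scatter) lies beyond the scatter. Compound 3 `CCC/C=C\C(=O)Nc1cc(Nc2ncc(C#N)c(-c3cn(C)c4ccccc34)n2)c(OC)cc1N(C)CCN(C)C` differs from compound 2 by cyano in place of hydrogen on an aromatic carbon. Within the data shown here, the single measured step concerns the acyl group and has no bearing on this change; no measured pair shows the effect of a cyano group here. With no guide in the data, the expected step of a 1.1-fold lower number from compound 2 to compound 3 (0.03 log units; within the scatter) is none beyond the scatter. Compound 3 is therefore estimated at 400 nM, within 120 nM to 1400 nM.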

Compound 3, half-maximal inhibitory concentration: 1690 nM
Beside the measured number, compound 3's estimate is 4.2-fold (0.63 log units) below it; the measured number lies above the stated range.
By their numbers in this assay, from the lowest: compound 2; then compound 3; then compound 1.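

The cyano change shows that this ring position is not indifferent: in this assay cyano in place of hydrogen on the aromatic carbon ortho to the 1-methyl-1H-indol-3-yl group brings a 3.9-fold higher number from compound 2 to compound 3 (0.59 log units; beyond the scatter) and so moves the number upward. Among these compounds, until now, the only measured step lay in the acyl group, so the ring carbon is a second place where a single change alters the result. Nothing measured here accounts for this shift.

Going by these compounds, whether chloro, fluoro or methyl at this carbon would move the number as cyano does remains open. So does the size of the cyano step when the acyl group is the 1-fluoroethenyl of compound 1.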